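Pyridin-3-yl in place of 3-methoxyphenyl on the alkyne

The compounds below may be only part of what the source reports. "The series", "measured", "known", "first", "only" and "open" are said of these compounds alone.

The shared core of this small set is seen in compound 1 `Cc1cccc(C#Cc2ccc3c(n2)CCN(C2CCCC2)C3=O)c1`, which carries a 3-methylphenyl on the triple-bonded carbon. In an assay on HEK293 cells for displacement of a labelled ligand from metabotropic glutamate receptor 5 (Homo sapiens), with a stated time of 2 h (on this read-out lower numbers stand for stronger inhibition and higher numbers for weaker inhibition), compound 1 gives 670 nM. Compound 2 `Cc1ccc(C#Cc2ccc3c(n2)CCN(C2CCCC2)C3=O)cc1` moves the methyl to give 4-methylphenyl. For compound 2 this assay reports only a limit, > 32000 nM. Compound 3 `COc1cccc(C#Cc2ccc3c(n2)CCN(C2CCCC2)C3=O)c1` carries a methoxy instead of the methyl on the aromatic carbon. For compound 3 too this assay reports only a limit, > 32000 nM. Thus compound 3 sits at the limit of > 32000 nM in this assay, at which 2 of the 3 values shown sit, and both steps away from compound 1 are large: an at least 47-fold higher number from compound 1 to compound 2 (1.67 log units; beyond the scatter) and an at least 47-fold higher number from compound 1 to compound 3 (1.67 log units; beyond the scatter). The step that the two limits leave unreadable from compound 2 to compound 3 cannot be read.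

Compound 4 `O=C1c2ccc(C#Cc3cccnc3)nc2CCN1C1CCCC1` is the compound not yet measured. It differs from compound 3 by pyridin-3-yl in place of 3-methoxyphenyl on a triple-bonded carbon. For the measured compounds named here, no measured step exchanges the ring itself; the two large losses seen so far came from moving or altering the substituent on the phenyl. Compound 3 stands at a limit, so the step from it can only be read as a return toward measurable binding or none. He expects compound 4 to come back into the measurable range, giving an estimated at least 16-fold lower number from compound 3 to compound 4 (1.20 log units; beyond the scatter) in this assay. He estimates for compound 4 a value of 2000 nM, in the range 300 nM to 20000 nM.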

Compound 4, inhibition constant: > 32000 nM
Compound 4 was reported as a limit; the forecaster's own chance of this, stated with the estimate: 25%; at least 16-fold (1.20 log units) between middle value and limit.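

For the compounds shown here, this result adds a different kind of change to the set: the phenyl ring itself is exchanged, where the earlier compounds only moved or altered its substituent. Compound 4 stands at a limit of the assay, not at a number, and it joins the other compounds there: the limit of > 32000 nM in this assay, at which 3 of the 4 values shown sit. Measured against the only number in the set, pyridin-3-yl in place of 3-methylphenyl on the triple-bonded carbon gives an at least 47-fold higher number from compound 1 to compound 4 (1.67 log units; beyond the scatter), so among the four compounds shown, only the 3-methylphenyl of compound 1 gives a measurable value, while the steps to compound 4 from compound 2 and from compound 3 cannot be read, since both ends of each are limits.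

The compounds shown leave open whether the measurable binding of compound 1 depends on the methyl itself or would also appear with 3-ethylphenyl or 3-chlorophenyl on the triple-bonded carbon. They also leave open whether a methyl added to the pyridin-3-yl ring would bring a value back into range, and how compound 2, compound 3 and compound 4 differ from one another beyond the limit.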